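The source may report more compounds than this note shows. Statements on the series, on what has been measured and on what is new or still open speak of the compounds shown alone.

Measured so far in an assay on isolated protein for binding affinity to leukotriene B4 receptor 1 (Homo sapiens), tested at 1 uM; on this read-out lower numbers stand for less inhibition and higher numbers for more inhibition at the one concentration tested (going by the name of the read-out):
- compound 1 `CCc1cc(C(C)=O)c(O)cc1OCCCCC#N`: 57%
- compound 2 `CCCCCc1cc(C(C)=O)c(O)cc1OCCCCC#N`: 14%
- compound 3 `C=CCc1cc(C(C)=O)c(O)cc1OCCCCC#N`: 57%

Compound 1 and compound 3 sit level at the digits printed, together the highest of the three numbers; compound 2 sits apart, with a drop a number 43 percentage points lower from compound 1 to compound 2 (beyond the scatter). The step of no change at the digits printed from compound 1 to compound 3 (within the scatter) shows that exchanging the group on the carbon bound to the aromatic carbon leaves this assay unchanged, whereas extending that same group by three carbons costs most of the inhibition a number 43 percentage points higher from compound 2 to compound 3 (beyond the scatter).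

Compound 4 `CCc1cc(C(C)=O)c(O)cc1OCCCCCCC(C)(C)C#N` differs from compound 1 as follows: 3-cyano-3-methylbutyl in place of cyano on a saturated chain carbon, four bonds along the chain from an oxygen on an aromatic ring. Within the data shown here, no measured step touches this chain; the measured steps all lie on the carbon bound to the aromatic carbon. Only the indirect lesson remains that one small exchange left the number in this assay level, whereas a three-carbon extension made it lower. The present change adds five carbons at the chain end, so a loss in this assay is expected, though of uncertain size: compound 4 is estimated at 35% (range 8% to 65%), a step of a number 22 percentage points lower from compound 1 to compound 4 (beyond the scatter) that is expected to exceed the scatter.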

Compound 4, a percentage reported as inhibition, at one concentration (the size of the read-out at that concentration, not a potency): 30%
For compound 4 the middle estimate is 5 percentage points above the measured one, and the stated range covers the measured number.
By their numbers in this assay, from the lowest: compound 2; then compound 4; then compounds 1 and 3 (each within the scatter of the next).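

Working notes: in this assay, replacing cyano with 3-cyano-3-methylbutyl on a saturated chain carbon, four bonds along the chain from an oxygen on an aromatic ring, gives a number 27 percentage points lower from compound 1 to compound 4 (beyond the scatter). Among these compounds, this is the first sign that the nitrile-bearing chain on that oxygen also responds to change, not just the group on the carbon bound to the aromatic carbon. Inhibition at the one concentration tested falls with this larger group but is not lost, and nothing at hand gives a reason for the fall.

The single change lengthens the chain and adds branching together, so the compounds shown do not separate the two contributions to the step. Also open, as far as these compounds go, is how this assay would respond if a carboxylic acid or an amine took the place of the terminal nitrile on the chain of compound 1.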